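The source may report more compounds than this note shows. Statements on the series, on what has been measured and on what is new or still open speak of the compounds shown alone.

Measured in a functional assay on DU-145 cells (Homo sapiens) for inhibition, read by trypan blue exclusion, with a stated time of 96 h; a higher number here means a weaker inhibitor of growth, a lower number a stronger inhibitor of growth:
Compound 1 `O=C(/C(=C\c1ccccc1F)S(=O)(=O)c1ccc(Br)cc1)c1ccc(Cl)cc1`: 25000 nM
Compound 2 `CN(C)c1ccc(/C=C(\C(=O)c2ccc(Cl)cc2)S(=O)(=O)c2ccc(Br)cc2)cc1`: > 100000 nM (a limit, not a number)

Compound 2 is known only through a limit, the weak end of the two values: the limit of > 100000 nM in this assay, at which 1 of the 2 values shown sits. Compound 3 `COc1ccc(/C=C(\C(=O)c2ccc(Cl)cc2)S(=O)(=O)c2ccc(Br)cc2)cc1O` is reached by 3-hydroxy-4-methoxyphenyl in place of 4-(dimethylamino)phenyl on a double-bonded chain carbon bound to a double-bonded chain carbon. Among the measured compounds shown here, one measured step bears on this place, an at least 4.0-fold higher number from compound 1 to compound 2 (0.60 log units; beyond the scatter), which brought in the group that compound 3 now loses. A single step is thin support, but a move toward a lower number in this assay is expected, toward the level of compound 1 at 25000 nM. The expected step is an at least 5.0-fold lower number from compound 2 to compound 3 (0.69 log units; beyond the scatter). For compound 3 the estimated value is 20000 nM, with an expected range of 4000 nM to 90000 nM.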

Compound 3, concentration for 50% growth inhibition: 10000 nM
Compound 3: middle estimate off by 2.0-fold (0.30 log units), on the high side; the range from low to high includes it.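

At the place on a double-bonded chain carbon bound to a double-bonded chain carbon, a change of aryl group can restore growth inhibition in this assay: 3-hydroxy-4-methoxyphenyl gives an at least 10-fold lower number from compound 2 to compound 3 (1.00 log units; beyond the scatter). Compound 2 is a limit, not a number, so that step has no fixed size: the limit of > 100000 nM in this assay, at which 1 of the 3 values shown sits. The same group also improves on 2-fluorophenyl, with a 2.5-fold lower number from compound 1 to compound 3 (0.40 log units; beyond the scatter), leaving compound 3 the strongest of the three.

The hydroxy and methoxy groups enter together, so their separate shares remain unresolved. As far as these compounds go, how a phenyl carrying a carboxylic acid or a primary amine would read at this place also stays open.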